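Trifluoromethyl for chloro beside the methanesulfonamide

The source may report more compounds than this note shows. Statements on the series, on what has been measured and on what is new or still open speak of the compounds shown alone.

Compound 1 `O=C(Nc1cccc(-c2nc(-c3ccc(NC(=O)c4cccnc4)cc3Cl)no2)c1)Nc1ccc(Cl)c(C(F)(F)F)c1`: 1900 nM
Compound 2 `CS(=O)(=O)Nc1ccc(NC(=O)Nc2cccc(-c3nc(-c4ccc(NC(=O)c5cccnc5)cc4Cl)no3)c2)cc1`: 600 nM
Compound 3 `CS(=O)(=O)Nc1ccc(NC(=O)Nc2cccc(-c3nc(-c4ccc(NC(=O)c5cccnc5)cc4Cl)no3)c2)cc1Cl`: 600 nM

In a functional assay on MDA-MB-231 cells (Homo sapiens) for antiproliferative activity, read by MTT assay, with a stated time of 72 h (on this read-out lower numbers stand for stronger inhibition and higher numbers for weaker inhibition), compound 3 gives 600 nM. It stands level with compound 2 at the digits shown, the two together giving the lowest numbers of the three; compound 1, the furthest of them, gives 1900 nM, and the step of a 3.2-fold lower number from compound 1 to compound 3 (0.50 log units; beyond the scatter) lies beyond the scatter. The step of no change at the digits printed from compound 2 to compound 3 (within the scatter) lies within the scatter.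

Compound 4 `CS(=O)(=O)Nc1ccc(NC(=O)Nc2cccc(-c3nc(-c4ccc(NC(=O)c5cccnc5)cc4Cl)no3)c2)cc1C(F)(F)F` differs from compound 3 by one change: trifluoromethyl in place of chloro on an aromatic carbon. Within the data shown here, no measured step exchanges chloro for trifluoromethyl at this position, so the bearing of the measured steps is indirect. The closest comparison is no change at the digits printed from compound 2 to compound 3 (within the scatter), where adding a chloro at this carbon left the number unchanged. Compound 4 is therefore expected to give a step of a 1.1-fold higher number from compound 3 to compound 4 (0.03 log units; within the scatter), that is, no change beyond the scatter. On that basis compound 4 is estimated at 650 nM, within a range from 300 nM to 1500 nM.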

Compound 4, half-maximal inhibitory concentration: 700 nM
Compound 4: the middle estimate sits 1.1-fold (0.03 log units) below what was measured, within the range that was stated.
By their numbers in this assay, from the lowest: compounds 2, 3 and 4 (each within the scatter of the next); then compound 1.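

In this assay, the position ortho to a methanesulfonamido group now tolerates three substituents without a step beyond the scatter: trifluoromethyl in place of chloro gives a 1.2-fold higher number from compound 3 to compound 4 (0.07 log units; within the scatter), and trifluoromethyl in place of hydrogen gives a 1.2-fold higher number from compound 2 to compound 4 (0.07 log units; within the scatter), although trifluoromethyl has 4 heavy atoms against 1 for chloro. Compound 4 also keeps the trifluoromethyl group of compound 1, so methanesulfonamido in place of chloro stands as a single change, with a 2.7-fold lower number from compound 1 to compound 4 (0.43 log units; beyond the scatter), which lies beyond the scatter. No evidence at hand bears on what lies behind these steps.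

As far as these compounds go, whether this tolerance extends to an amine, a carboxylic acid or a methoxy group at this carbon stays open. So does the effect of a longer chain in place of the methyl on the sulfonyl group.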